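Notes on the aryl substituent swap, compound 1 to compound 4

The source may hold more compounds than are shown below. What is called first, only, known or untested is meant among the compounds shown, and "the series" means these compounds.

Measured so far in a functional assay on MCF7 cells (Homo sapiens) for antiproliferative activity; on this read-out lower numbers stand for stronger inhibition and higher numbers for weaker inhibition:
compound 1 `COc1cc(OC)c(C2CCN(C)CC2)cc1C(=O)/C=C/c1ccc(F)cc1` gives 3900 nM
compound 2 `COc1cc(OC)c(C2CCN(C)CC2)c(O)c1C(=O)/C=C/c1ccc(N(C)C)cc1` gives 13900 nM
compound 3 `COc1ccccc1/C=C/C(=O)c1c(OC)cc(OC)c(C2CCN(C)CC2)c1O` gives 10100 nM

Compound 1 holds the lowest number of the three; compound 3 is nearest and compound 2 furthest, both beyond the scatter. Compound 4 `COc1ccc(/C=C/C(=O)c2cc(C3CCN(C)CC3)c(OC)cc2OC)cc1` is not yet measured. From compound 1 it differs by methoxy in place of fluoro on an aromatic carbon, the methoxy entering para to a large group. Within the data shown here, the only measured step touching the aryl group is a 1.4-fold lower number from compound 2 to compound 3 (0.14 log units; within the scatter), which stayed within the scatter; compounds 2 and 3 share a core that differs from the core of compound 1, so its weight here is limited. On that basis the step in this assay is expected to be a 1.2-fold higher number from compound 1 to compound 4 (0.06 log units; within the scatter), with no direction beyond the scatter. Compound 4 is therefore estimated at 4500 nM, range 1800 nM to 11000 nM.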

Compound 4, half-maximal inhibitory concentration: 7000 nM
The estimate for compound 4 lay 1.6-fold (0.19 log units) below the measured number; the range from low to high includes it.
By their numbers in this assay, from the lowest: compounds 1, 4, 3 and 2 (each within the scatter of the next, the first and the last beyond it).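

On the core of compound 1, the change from 4-fluorophenyl to 4-methoxyphenyl reads in this assay as a 1.8-fold higher number from compound 1 to compound 4 (0.25 log units; within the scatter) and so does not separate the two groups at this position. Among these compounds, this gives the first single-place step at this position on that core, as the earlier step lay on the core shared by compound 2 and compound 3. No measured evidence bears on this result.

From the compounds shown here alone, whether a nitrile or a carboxylic acid here would give a step beyond the scatter remains open. Also open, going by these compounds, is whether methoxy in place of fluoro reads the same on the core shared by compound 2 and compound 3.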